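Chain extension from compound 3 to compound 4

The source may report more compounds than this note shows. Statements on the series, on what has been measured and on what is new or still open speak of the compounds shown alone.

In a functional assay on CHO cells (Cricetulus griseus) for inhibition (a lower number here means a stronger inhibitor, a higher number a weaker inhibitor), compound 3 (`CCCCCCCCCCCCCC(=O)N[C@@H](CO)C[C@@H](O)c1ccccc1`) gives 70 nM and compound 2 (`CCCCCCCCCCCC(=O)N[C@@H](CO)C[C@@H](O)c1ccccc1`) gives 70 nM, so the two stand level. Compound 1 (`CCCCCCCCCCCCCCCC(=O)N[C@@H](CO)C[C@@H](O)c1ccccc1`) gives > 1000 nM, which is a limit and not a number.

Compound 4 (`CCCCCCCCCCCCCCCCC(=O)N[C@@H](CO)C[C@@H](O)c1ccccc1`) differs from compound 3 by propyl in place of hydrogen on a saturated chain carbon, ten or more bonds along the chain from a carbonyl carbon.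

Among the measured compounds shown here, three measured steps bear on this change. Adding ethyl at this place made no difference in one case: no change at the digits printed from compound 2 to compound 3 (within the scatter). The other two steps are large and both start from the limit of compound 1: an at least 14-fold lower number from compound 1 to compound 3 (1.15 log units; beyond the scatter) and an at least 14-fold lower number from compound 1 to compound 2 (1.15 log units; beyond the scatter). Read backwards, the second of these links ethyl on compound 3 to a large loss, and the first shows that such a loss does not always follow. The propyl of compound 4 is larger than that ethyl, so a large step towards weaker inhibition is expected rather than none.

The expected step is a 21-fold higher number from compound 3 to compound 4 (1.33 log units; beyond the scatter). The estimate for compound 4 is 1500 nM, with an expected range of 400 nM to 6000 nM, and a report as a limit alone is also expected to be likely.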

Compound 4, half-maximal inhibitory concentration: > 1000 nM
Compound 4 gave a limit, no number; the forecaster's own chance of this, stated with the estimate: 65%; the middle value lies beyond the limit too.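

In this assay, propyl in place of hydrogen on a saturated chain carbon, ten or more bonds along the chain from a carbonyl carbon, gives an at least 14-fold higher number from compound 3 to compound 4 (1.15 log units; beyond the scatter), and pentyl in place of hydrogen at the same place gives an at least 14-fold higher number from compound 2 to compound 4 (1.15 log units; beyond the scatter). The earlier compounds read such a loss only backwards from compound 1, whereas these steps start from the two measured chains and set it against the ethyl step, no change at the digits printed from compound 2 to compound 3 (within the scatter), so among the compounds shown, only the chain of compound 2 and the chain of compound 3 hold inhibition in this assay. The value of compound 4 is a limit, as is that of compound 1, so the step from compound 1 to compound 4 cannot be read and the two chains cannot be ranked: the limit of > 1000 nM in this assay, at which 2 of the 4 values shown sit.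

From the compounds shown here alone, how far inhibition falls past that limit for compound 1 and compound 4 remains open. Also open, going by these compounds, is whether a shorter chain than that of compound 2, or a longer chain ending in a carboxylic acid or an amine, would stand level with compound 2 and compound 3.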